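Replacing the fluoro of compound 1 with a benzyl ether

A few compounds are considered here, and "the series" means these few. Any claim that something is new, unique, unknown or untested is made for them only; others in the source may bear on it.

Within the data shown here, compound 1 `COc1cc2ncnc(Nc3ccc(F)c(Cl)c3)c2cc1OCCCCC(=O)Nc1ccc(S(N)(=O)=O)cc1` gives 35600 nM in a functional assay on NCI-H1975 cells (Homo sapiens) for antiproliferative activity, read by MTT assay, with a stated time of 72 h (on this read-out lower numbers stand for stronger inhibition and higher numbers for weaker inhibition), the highest number among the three measured members. Compound 2 `COc1cc2ncnc(Nc3ccc(F)c(Br)c3)c2cc1OCCCCC(=O)Nc1ccc(S(N)(=O)=O)cc1` gives 31600 nM and compound 3 `COc1cc2ncnc(Nc3ccc(C(F)(F)F)cc3)c2cc1OCCCCC(=O)Nc1ccc(S(N)(=O)=O)cc1` gives 12000 nM in this assay. Every step measured so far alters only the group on the amino nitrogen of the shared core: a 1.1-fold lower number from compound 1 to compound 2 (0.05 log units; within the scatter), a 3.0-fold lower number from compound 1 to compound 3 (0.47 log units; beyond the scatter) and a 2.6-fold lower number from compound 2 to compound 3 (0.42 log units; beyond the scatter).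

Compound 4 `COc1cc2ncnc(Nc3ccc(OCc4cccc(F)c4)c(Cl)c3)c2cc1OCCCCC(=O)Nc1ccc(S(N)(=O)=O)cc1` differs from compound 1 by (3-fluorobenzyl)oxy in place of fluoro on an aromatic carbon. Among the measured compounds shown here, no measured step covers a change of this kind. The nearest precedents are the two steps that exchange the whole group on the amino nitrogen, a 3.0-fold lower number from compound 1 to compound 3 (0.47 log units; beyond the scatter) and a 2.6-fold lower number from compound 2 to compound 3 (0.42 log units; beyond the scatter), each a modest lowering, whereas the halogen swap a 1.1-fold lower number from compound 1 to compound 2 (0.05 log units; within the scatter) stayed within the scatter. Because a 3.0-fold lower number from compound 1 to compound 3 (0.47 log units; beyond the scatter) brought only a modest lowering, the step expected for compound 4 is a 2.4-fold lower number from compound 1 to compound 4 (0.38 log units; beyond the scatter), downward in direction but with wide uncertainty, since nothing in the set tests a group of this size at this place. The estimate for compound 4 in this assay is 15000 nM, with a range from 4000 nM to 50000 nM.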

Compound 4, half-maximal inhibitory concentration: 5670 nM
Compound 4: the middle estimate sits 2.6-fold (0.42 log units) above what was measured; the measured number falls inside the stated range.
By their numbers in this assay, from the lowest: compound 4; then compound 3; then compounds 2 and 1 (each within the scatter of the next).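

Among these compounds, the position para to a large group, ortho to the chloro group, held only fluoro, chloro-adjacent halogen variation aside, in the earlier compounds; it now proves open to a far larger substituent, as (3-fluorobenzyl)oxy, with 9 heavy atoms and a six-membered aromatic ring, replaces fluoro with a 6.3-fold lower number from compound 1 to compound 4 (0.80 log units; beyond the scatter) in this assay. Among the compounds shown here, the earlier steps only swapped a halogen or exchanged the whole group on the amino nitrogen, so this is the first step to show that adding bulk on this aromatic carbon lowers the number rather than raising it, although compound 4 still stands at 5670 nM on this read-out. No measurement on hand accounts for the step.

As far as these compounds go, whether the lowering needs the whole (3-fluorobenzyl)oxy group remains open, since a methoxy, an unsubstituted benzyloxy or a pyridylmethoxy group at this place would separate the contributions of the ether oxygen, the ring and the ring fluorine. Also open, from the compounds shown here alone, is whether the same change carries over to the bromo analogue, compound 2, or to a shorter chain linking the shared core to the sulfonamide-bearing anilide.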